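Shrinking the ring on the amide: compound 3 to compound 4

A few compounds are considered here, and "the series" means these few. Any claim that something is new, unique, unknown or untested is made for them only; others in the source may bear on it.

Measured compounds:
Compound 1, `O=C(c1sc(-c2cccc(F)c2)nc1O)N1CCCCO1`, 167 nM
Compound 2, `CON(C)C(=O)c1sc(-c2cccc(F)c2)nc1O`, 96 nM
Compound 3, `O=C(c1sc(-c2cccc(F)c2)nc1O)N1CCCCCO1`, 32 nM

All three were tested in an assay on HEK293 cells for inhibition of transient receptor potential cation channel subfamily M member 8 (Homo sapiens), read by FLIPR, with stated times of 5 min and 3 min; a lower number here means a stronger inhibitor, a higher number a weaker inhibitor. Compound 3 stands lowest of the three numbers: its nearest neighbour is compound 2, as the step of a 3.0-fold lower number from compound 2 to compound 3 (0.48 log units; beyond the scatter) shows, and its furthest is compound 1, as the step of a 5.2-fold lower number from compound 1 to compound 3 (0.72 log units; beyond the scatter) shows. Both steps go beyond the scatter, so compound 3 is the strongest inhibitor among the measured three.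

Compound 4, `O=C(c1sc(-c2cccc(F)c2)nc1O)N1CCOCC1`, differs from compound 3 in one place: a group of 6 heavy atoms (4 carbon, 1 nitrogen, 1 oxygen; one six-membered non-aromatic ring with 2 hetero atoms) in place of a group of 7 heavy atoms (5 carbon, 1 nitrogen, 1 oxygen; one seven-membered non-aromatic ring with 2 hetero atoms), on a carbonyl carbon. This is close to a reversal of the step from compound 1 to compound 3, in which a six-membered non-aromatic ring with 2 hetero atoms gave way to the seven-membered one, and that step lowered the number modestly. The ring in compound 4 is not the same six-membered ring as in compound 1, so no direct comparison exists. Still, the two measured steps point the same way: returning to a smaller group is expected to give a higher number. For compound 4 the expected step is a 3.8-fold higher number from compound 3 to compound 4 (0.57 log units; beyond the scatter), and the estimate for compound 4 is 120 nM, with a range from 50 nM to 300 nM.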

Compound 4, half-maximal inhibitory concentration: 12200 nM
Compound 4: the middle estimate sits 100-fold (2.01 log units) below what was measured; the measured number lies above the stated range.
By their numbers in this assay, from the lowest: compound 3; then compounds 2 and 1 (each within the scatter of the next); then compound 4.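

In this assay the morpholin-4-yl amide is the weakest inhibitor shown, with steps (a 380-fold higher number from compound 3 to compound 4 (2.58 log units; beyond the scatter)), (a 130-fold higher number from compound 2 to compound 4 (2.10 log units; beyond the scatter)) and (a 73-fold higher number from compound 1 to compound 4 (1.86 log units; beyond the scatter)). The last step matters most: the groups on the carbonyl carbon of compound 1 and compound 4 have the same heavy atoms and the same ring size, so at this position neither atom count nor ring size alone sets the number, and the arrangement of the ring atoms can change it greatly. Nothing measured here explains this loss.

As far as these compounds go, it remains open how much of the loss belongs to the ring oxygen of morpholin-4-yl. A piperidin-1-yl amide, with carbon in place of that oxygen, and an open-chain dimethylamino amide would help to separate the effect of that oxygen from that of the ring.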